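A few compounds are considered here, and "the series" means these few. Any claim that something is new, unique, unknown or untested is made for them only; others in the source may bear on it.

Compound 2 `COc1cc2cc(Oc3ccc(NC(=O)Nc4ccc(Cl)c(C(F)(F)F)c4)cc3)c(C)nc2cc1OC` gives -43.6% in a functional assay on NCI-H522 cells (Homo sapiens) for inhibition, read by sulforhodamine B assay, with a stated time of 48 h, tested at 10 uM; on this read-out lower numbers stand for a stronger effect and higher numbers for a weaker effect at the one concentration tested. For the measured compounds named here, its only measured companion is compound 1 `COc1cc2cc(Oc3ccc(NC(=O)Nc4cccc(C(F)(F)F)c4)cc3)c(C)nc2cc1OC`, which in this assay gives -17.4%; the step of a number 26.2 percentage points lower from compound 1 to compound 2 (beyond the scatter) sets compound 2 at the lowest of the two numbers. Compound 3 `COc1cc2cc(Oc3ccc(NC(=O)Nc4ccc(Cl)c(Cl)c4)cc3)c(C)nc2cc1OC` has not been measured. It differs from compound 2 by chloro in place of trifluoromethyl on an aromatic carbon. Going by the values given here, the one measured step, chloro in place of hydrogen on an aromatic carbon, does not involve the trifluoromethyl group that now leaves, so no measured step bears directly on this change. Without such a step, the expectation for compound 3 rests on compound 2 alone, with a wide range and no clear direction; the step of a number 11.6 percentage points higher from compound 2 to compound 3 (beyond the scatter) is estimated to stay within the scatter. Compound 3 is accordingly expected to give -32% in this assay, between -62% and -2%.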

Compound 3, a percentage reported as activity, at one concentration (the size of the read-out at that concentration, not a potency): -13.8%
Compound 3: the middle estimate sits 18.2 percentage points below what was measured; the measured number falls inside the stated range.
By their numbers in this assay, from the lowest: compound 2; then compounds 1 and 3 (each within the scatter of the next).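

Exchanging trifluoromethyl for chloro at this place, ortho to a chloro group, gives a number 29.8 percentage points higher from compound 2 to compound 3 (beyond the scatter) in this assay and shows that the two groups are not interchangeable here. The other new step, a number 3.6 percentage points higher from compound 1 to compound 3 (within the scatter) in this assay as well, leaves 3,4-dichlorophenyl and 3-(trifluoromethyl)phenyl indistinguishable, so among these three compounds only the 4-chloro-3-(trifluoromethyl)phenyl group stands out. Nothing available explains why the two groups part in this way.

The compounds shown leave open how a bromo, a nitrile, a methoxy or an amine at this place would compare with trifluoromethyl and chloro. They also leave open whether the gap between these groups would persist with a different substituent in place of the neighbouring chloro group on the same ring.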